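This account rests on a few compounds, and the source may have more. Where it says the series, first, only, none or still open, it means among the compounds named here.

Measured compounds in an ADME assay on microsomes from liver (Homo sapiens) for pharmacokinetics; on this read-out higher numbers stand for fast clearance and lower numbers for slow clearance:

- compound 1 `Cc1nn(CC2(O)COC2)cc1Nc1nc(N)c2c(C#N)c(N3CCC[C@H]3C)n(C)c2n1`: 76.7 mL/min/kg
- compound 2 `Cc1nn(C)cc1Nc1nc(N)c2c(C#N)c(N3CCC[C@H]3C)n(C)c2n1`: 70 mL/min/kg
- compound 3 `C[C@@H]1CCCN1c1c(C#N)c2c(N)nc(Nc3cn(C)nc3Cl)nc2n1C`: 183 mL/min/kg

Compound 3 gives the highest of the three numbers in this assay. Its nearest neighbour on that read-out is compound 1 and its furthest is compound 2; both of those gaps lie beyond the scatter, so compound 3 is cleared fastest of the three.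

The next step leads to compound 4 `C[C@@H]1CCCN1c1c(C#N)c2c(N)nc(Nc3cn(C)nc3C(F)(F)F)nc2n1C`, which is not yet measured. Relative to compound 3 the change is trifluoromethyl in place of chloro on an aromatic carbon.

Two steps are available for comparison. The step of a 1.1-fold lower number from compound 1 to compound 2 (0.04 log units; within the scatter) lies within the scatter and concerns a remote position, so it says little here. The step of a 2.6-fold higher number from compound 2 to compound 3 (0.42 log units; beyond the scatter) concerns the same aromatic carbon but exchanges methyl for chloro, not chloro for trifluoromethyl, so it only shows that this position can move the number. Going by the values given here, no measured pair exchanges a halogen for a trifluoromethyl group anywhere.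

With nothing directly comparable, the expectation for compound 4 in this assay is a step of a 1.1-fold lower number from compound 3 to compound 4 (0.03 log units; within the scatter), that is, no change beyond the scatter. The estimate for compound 4 is 170 mL/min/kg, with a range from 85 mL/min/kg to 340 mL/min/kg.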

Compound 4, clearance: 33.3 mL/min/kg
Beside the measured number, compound 4's estimate is 5.1-fold (0.71 log units) above it, outside the stated range (below it).
By their numbers in this assay, from the lowest: compound 4; then compounds 2 and 1 (each within the scatter of the next); then compound 3.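

Trifluoromethyl in place of chloro on this aromatic carbon of the five-membered aromatic ring gives a 5.5-fold lower number from compound 3 to compound 4 (0.74 log units; beyond the scatter) in this assay. The earlier step at this carbon, a 2.6-fold higher number from compound 2 to compound 3 (0.42 log units; beyond the scatter), showed only a rise, so the position can move the number in either direction, and trifluoromethyl also sits apart from methyl, with a 2.1-fold lower number from compound 2 to compound 4 (0.32 log units; beyond the scatter); across these three compounds the numbers run from trifluoromethyl through methyl to chloro, each gap beyond the scatter, and chloro and methyl, at one heavy atom each, already differ. Nothing available here explains why these groups order this way.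

As far as these compounds go, it remains open whether the low number is particular to trifluoromethyl or extends to other groups on this carbon, such as difluoromethyl, bromo or methoxy. From the compounds shown here alone, it is also open whether the step from chloro to trifluoromethyl holds when the methyl group on the ring nitrogen gives way to a longer chain or to the 3-hydroxyoxetan-3-yl group on a saturated chain carbon seen in compound 1.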